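A few compounds are considered here, and "the series" means these few. Any claim that something is new, unique, unknown or untested is made for them only; others in the source may bear on it.

Compound 1 `COc1cc(-n2cnc3ccc(-c4ccc([N+](=O)[O-])cc4)cc32)cc(OC)c1OC`: 740 nM
Compound 2 `COc1cc(-n2cnc3ccc(-c4ccc(Cl)cc4)cc32)cc(OC)c1OC`: 1320 nM

In a functional assay on MCF7 cells (Homo sapiens) for antiproliferative activity, read by MTT assay, with a stated time of 72 h (on this read-out higher numbers stand for weaker inhibition and lower numbers for stronger inhibition), compound 2 gives 1320 nM, level with compound 1 once the usual scatter is allowed for. Compound 3 `COc1ccc(-c2ccc3ncn(-c4cc(OC)c(OC)c(OC)c4)c3c2)cc1` is still unmeasured and differs from compound 2 by methoxy in place of chloro on an aromatic carbon. Within the data shown here, the one measured step that bears on this is also a swap on an aromatic carbon: a 1.8-fold higher number from compound 1 to compound 2 (0.25 log units; within the scatter). It stays within the scatter, so no step beyond the scatter is expected in this assay. The estimated change is a 1.3-fold lower number from compound 2 to compound 3 (0.12 log units; within the scatter). Compound 3 is expected at 1000 nM, with an estimated range from 400 nM to 2500 nM.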

Compound 3, half-maximal inhibitory concentration: 210 nM
Beside the measured number, compound 3's estimate is 4.8-fold (0.68 log units) above it, and the stated range ends above it.
By their numbers in this assay, from the lowest: compound 3; then compounds 1 and 2 (each within the scatter of the next).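

Here, on an aromatic carbon para to a large group, the choice of group does count: methoxy in place of chloro gives a 6.3-fold lower number from compound 2 to compound 3 (0.80 log units; beyond the scatter) in this assay and methoxy in place of nitro gives a 3.5-fold lower number from compound 1 to compound 3 (0.55 log units; beyond the scatter) on the same read-out. Among these compounds, the earlier swap of nitro for chloro stayed within the scatter, so methoxy is the first group here to stand apart from the others. No measurement shown gives a reason for this. Still open, as far as these compounds go, is how an amine, a hydroxyl or a longer chain such as ethoxy would read at this position. From the compounds shown here alone, whether the gain would carry over to other cell lines also remains unknown.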